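Removing One Methyl from Compound 1

The source may report more compounds than this note shows. Statements on the series, on what has been measured and on what is new or still open speak of the compounds shown alone.

Compound 1 `COc1ccc2nc(C)cc(OCC(=O)Nc3cc(C)cc(C)c3)c2c1` stands lowest of the three measured compounds in a physicochemical assay for lipophilicity, read by HPLC, in phosphate buffer, measured as chromatographic lipophilicity, at pH 7.4 (a higher number here means a more lipophilic compound, a lower number a more polar compound), where compound 1 gives 5.64. Its nearest neighbour is compound 3 `CCCc1cc(OCC(=O)Nc2cc(C)cc(C)c2)c2cc(OC)ccc2n1`, which in this assay gives 6.44; furthest away is compound 2 `Cc1cc(C)cc(NC(=O)COc2cc(C)nc3ccc(OCc4ccccc4)cc23)c1`, which gives 7.03. Both measured steps replace a hydrogen with a carbon group: a number 1.39 log units higher from compound 1 to compound 2 (beyond the scatter) and a number 0.80 log units higher from compound 1 to compound 3 (beyond the scatter). Compound 4 `COc1ccc2nc(C)cc(OCC(=O)Nc3cccc(C)c3)c2c1` is compound 1 with the change (hydrogen in place of methyl on an aromatic carbon), that is, 3,5-dimethylphenyl to 3-methylphenyl, the hydrogen entering on a carbon that is meta to a large group and meta to a methyl group. Neither measured step matches this change, and both run the other way, adding carbon rather than taking it off. Since a number 0.80 log units higher from compound 1 to compound 3 (beyond the scatter) was the smaller of the two additions and only modest, the loss of a single carbon is expected to lower the number by less than that, though likely beyond the scatter. Compound 4 is therefore estimated at 5.25, within 4.95 to 5.55, which corresponds to an expected a number 0.39 log units lower from compound 1 to compound 4 (beyond the scatter).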

Compound 4, distribution coefficient: 4.83
Estimate against measurement, compound 4: 0.42 log units above; measured number outside the range, below it.
By their numbers in this assay, from the lowest: compound 4; then compound 1; then compound 3; then compound 2.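

In this assay, among the compounds shown here, this is the first step that takes carbon away and the first made on the 3,5-dimethylphenyl ring, and it shows that the number falls when a methyl on that ring gives way to hydrogen: a number 0.81 log units lower from compound 1 to compound 4 (beyond the scatter). The loss of this single methyl is of the same modest size as the gain from the ethyl entering at a different place, a number 0.80 log units higher from compound 1 to compound 3 (beyond the scatter), so a small change on this aromatic carbon counts for as much as that chain extension. No available evidence bears on why the step has this size.

The compounds shown leave open whether removing the remaining methyl would give a step of similar size. They also leave open how an amine, a carboxylic acid or a longer chain on this aromatic carbon would read in this assay.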